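Swapping the dichlorophenyl of compound 1 for a cyanophenyl

The compounds below may be only part of what the source reports. "The series", "measured", "known", "first", "only" and "open" are said of these compounds alone.

Measured compounds:
compound 1, `Cc1nc(-c2ccccc2)c(C(=O)N2CCN(c3cccc(Cl)c3Cl)CC2)o1`, 133 nM
compound 2, `CCc1nc(-c2ccc(F)cc2)c(C(=O)N2CCN(c3cccc(Cl)c3)CC2)o1`, 169 nM
compound 3, `Cc1ccc(C)c(N2CCN(C(=O)c3oc(C)nc3-c3cccc(Cl)c3)CC2)c1`, 345 nM

In a functional assay on HL-60 cells (Homo sapiens) for inhibition, read by MTT assay, with a stated time of 72 h (on this read-out higher numbers stand for weaker inhibition and lower numbers for stronger inhibition), compound 1 gives the lowest of the three numbers; compound 2 lies within the scatter of it, while compound 3 sits beyond the scatter above it. Compound 4, `Cc1nc(-c2ccccc2)c(C(=O)N2CCN(c3cccc(C#N)c3)CC2)o1`, has not yet been measured. It differs from compound 1 in one place: 3-cyanophenyl in place of 2,3-dichlorophenyl on an amine nitrogen in a ring. For the measured compounds named here, no measured pair shows this exact change, so the direction has to be judged from what the three measured aryl groups show, where varied substitution on that ring moved the read-out only modestly. A small weakening, close to the edge of the scatter, is expected from compound 1 to compound 4, a 2.0-fold higher number from compound 1 to compound 4 (0.29 log units; within the scatter). Compound 4 is therefore estimated at 260 nM, with a range from 100 nM to 700 nM.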

Compound 4, half-maximal inhibitory concentration: 39.6 nM
For compound 4 the middle estimate is 6.6-fold (0.82 log units) above the measured one, outside the stated range (below it).
By their numbers in this assay, from the lowest: compound 4; then compounds 1 and 2 (each within the scatter of the next); then compound 3.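

In this assay, the aryl group on the amine nitrogen of the ring proves to be a position where a single change moves the read-out beyond the scatter: 3-cyanophenyl in place of 2,3-dichlorophenyl gives a 3.4-fold lower number from compound 1 to compound 4 (0.53 log units; beyond the scatter). This first one-place step also shows that the position tolerates an aryl group without chlorine. Nothing shown explains why the number falls. As far as these compounds go, whether the nitrile or the loss of the chlorines drives the step remains open, as does how a methoxy group or a primary amide on that ring would behave.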